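This account rests on a few compounds, and the source may have more. Where it says the series, first, only, none or still open, it means among the compounds named here.

Working notes on the series in a functional assay on HeLa cells (Homo sapiens) for antiproliferative activity, read by CCK-8 assay, with a stated time of 72 h, tested at 2 uM; a lower number here means a weaker effect, a higher number a stronger effect of the compound at the concentration tested. Three analogues of a shared core have been measured. Compound 1 `Nc1ccccc1NC(=O)c1ccc(CSC(=S)N2CCN(c3ccc(Cl)cc3)CC2)cc1` gives 51.2%. Compound 2 `COc1ccc(N2CCN(C(=S)SCc3ccc(C(=O)Nc4ccccc4N)cc3)CC2)cc1` gives 39.4%. Compound 3 `Nc1ccccc1NC(=O)c1ccc(CSC(=S)N2CCN(c3ncccn3)CC2)cc1` gives 52.2%, the highest of the three numbers; one step to it is within the scatter, a number 1 percentage points higher from compound 1 to compound 3 (within the scatter), the other beyond it, a number 12.8 percentage points higher from compound 2 to compound 3 (beyond the scatter). Compound 4 `Nc1ccccc1NC(=O)c1ccc(CSC(=S)N2CCN(c3ccncc3)CC2)cc1` is not yet measured and differs from compound 3 in one place: pyridin-4-yl in place of pyrimidin-2-yl on an amine nitrogen in a ring. Within the data shown here, both measured steps that change the group on the amine nitrogen in the ring bear on this; the pyrimidin-2-yl of compound 3 sits within the scatter of the 4-chlorophenyl of compound 1 and modestly above the 4-methoxyphenyl of compound 2, so changes at this position have so far produced at most modest shifts, and no step exchanges one heteroaryl for another. A step in this assay of no more than modest size, most likely within the scatter, is expected. Compound 4 is therefore estimated at 48%, with a range from 35% to 60%, which means an expected step of a number 4.2 percentage points lower from compound 3 to compound 4 (within the scatter).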

Compound 4, a percentage reported as inhibition, at one concentration (the size of the read-out at that concentration, not a potency): 77%
Beside the measured number, compound 4's estimate is 29 percentage points below it; measured number outside the range, above it.
By their numbers in this assay, from the lowest: compound 2; then compounds 1 and 3 (each within the scatter of the next); then compound 4.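

In this assay, among these compounds, the amine nitrogen in the ring proves far more sensitive than the earlier compounds suggested: exchanging one heteroaryl for another, with one ring nitrogen in place of two, gives a number 24.8 percentage points higher from compound 3 to compound 4 (beyond the scatter). The pyridin-4-yl group also clears both substituted phenyl groups, with a number 25.8 percentage points higher from compound 1 to compound 4 (beyond the scatter) and a number 37.6 percentage points higher from compound 2 to compound 4 (beyond the scatter), so a heteroaryl alone does not account for the high number, as compound 3 stays within the scatter of compound 1. Nothing available on these compounds accounts for the size of this step.

Going by these compounds, whether the high number needs the ring nitrogen at the position found in pyridin-4-yl remains open, and pyridin-3-yl and pyridin-2-yl on the same amine nitrogen would address that. A single-concentration percentage also leaves the potency of compound 4 undefined.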